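The compounds below may be only part of what the source reports. "The series", "measured", "known", "first", "only" and "open" are said of these compounds alone.

Compound 1 `CCn1c(=O)cc(Cl)[s+]1[O-]` was tested first. In an assay on isolated protein for inhibition of histone acetyltransferase KAT2B (Homo sapiens), read by fluorescence, with a stated time of 15 min (on this read-out higher numbers stand for weaker inhibition and lower numbers for stronger inhibition), compound 1 gives > 10000 nM, which is a limit of the assay rather than a number. Compound 2 `CCn1c(=O)c(Cl)c(Cl)[s+]1[O-]` is its partner; compound 2 gives > 10000 nM, again a limit. Compound 3 `CCCCCCCCCCCCSc1cc(=O)n(CCC(=O)OC)[s+]1[O-]` gives > 10000 nM, also a limit.

Compound 1 and compound 2 differ by one change, (chloro in place of hydrogen on an aromatic carbon). The step that the two limits leave unreadable from compound 1 to compound 2 cannot be sized, because both values sit at the same limit (the limit of > 10000 nM in this assay, at which 3 of the 3 values shown sit). How the core of compound 3 differs from the core of compound 1 is not broken down here.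

Compound 4 `CCCCCCCCCCCCSc1c(Cl)c(=O)n(CCC(=O)OC)[s+]1[O-]` is not yet measured. It differs from compound 3 by chloro in place of hydrogen on an aromatic carbon. Within the data shown here, this is the same kind of change as the one from compound 1 to compound 2, not the same change: in compound 1 the carbon sits next to the ring atom that bears a chloro group and two ring bonds from the ring atom that bears an ethyl group, whereas in compound 3 it sits next to the ring atom that bears a large group and two ring bonds from the ring atom that bears a 2-(methoxycarbonyl)ethyl group.

For compound 4 in this assay the expected step is a step that the limit leaves unreadable from compound 3 to compound 4, set beside the unreadable step that the two limits leave unreadable from compound 1 to compound 2; this expectation rests on compound 3 giving > 10000 nM and on the limit (the limit of > 10000 nM in this assay, at which 3 of the 3 values shown sit). Compound 4 is therefore estimated at 20000 nM, between 5000 nM and 100000 nM.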

Compound 4, half-maximal inhibitory concentration: > 10000 nM
Compound 4 ended at the assay's limit (the forecaster's own chance of this, stated with the estimate: 85%); the middle value does not contradict the limit.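

In this assay compound 4 gives > 10000 nM, which is a limit and not a number. The step from compound 3 to compound 4 cannot be read, because both compounds sit at the same limit: the limit of > 10000 nM in this assay, at which 4 of the 4 values shown sit.

The compounds shown leave open whether chloro in place of hydrogen changes inhibition at all, and what structure would give a readable value in this assay.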